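Switching the aniline substituent on a quinazoline thiourea

A few compounds are considered here, and "the series" means these few. Any claim that something is new, unique, unknown or untested is made for them only; others in the source may bear on it.

Measured so far:
Compound 1, `COc1cc2ncnc(Nc3ccc(F)cc3)c2cc1OCCCCC(=O)Nc1ccc(S(N)(=O)=O)cc1`: > 40000 nM
Compound 2, `COc1cc2ncnc(Nc3ccc(OC(F)(F)F)cc3)c2cc1OCCCCC(=O)Nc1ccc(S(N)(=O)=O)cc1`: 8770 nM
Compound 3, `NS(=O)(=O)c1ccc(NC(=S)Nc2ccc3ncnc(Nc4ccc(F)c(Cl)c4)c3c2)cc1`: 15800 nM

All three were tested in a functional assay on NCI-H1975 cells (Homo sapiens) for antiproliferative activity, read by MTT assay, with a stated time of 72 h; on this read-out higher numbers stand for weaker inhibition and lower numbers for stronger inhibition. For compound 1 the result > 40000 nM is a limit of the assay, not a number (the limit of > 40000 nM in this assay, at which 1 of the 3 values shown sits). Among the two numbers, compound 3 has the higher one, but its nearest neighbour, compound 2, lies within the scatter of it, so the two cannot be ranked.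

Compound 4, `CCc1ccc(Nc2ncnc3ccc(NC(=S)Nc4ccc(S(N)(=O)=O)cc4)cc23)cc1`, has not yet been measured. It differs from compound 3 in one place: 4-ethylphenyl in place of 3-chloro-4-fluorophenyl on a nitrogen on an aromatic ring. Going by the values given here, the only measured step that touches the same region, the ring on the amino nitrogen, is an at least 4.5-fold lower number from compound 1 to compound 2 (0.65 log units; beyond the scatter), which shows that a change there can move the number well beyond the scatter. That step, however, concerns a different pair of groups, so it does not tell in which direction 4-ethylphenyl in place of 3-chloro-4-fluorophenyl will move the number.

For compound 4 in this assay the expected value is 12000 nM, within a range of 3000 nM to 40000 nM. The step of a 1.3-fold lower number from compound 3 to compound 4 (0.12 log units; within the scatter) is the estimated change, a shift that could fall on either side of the scatter.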

Compound 4, half-maximal inhibitory concentration: 38700 nM
Beside the measured number, compound 4's estimate is 3.2-fold (0.51 log units) below it; low and high end bracket the measured number.
By their numbers in this assay, from the lowest: compounds 2 and 3 (each within the scatter of the next); then compound 4. At a limit, above all of these: compound 1.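

On the thiourea compounds, the ring on the amino nitrogen now has a measured direction: in this assay, 4-ethylphenyl in place of 3-chloro-4-fluorophenyl gives a 2.4-fold higher number from compound 3 to compound 4 (0.39 log units; beyond the scatter). The step is modest but beyond the scatter, and it arises between two groups with the same count of heavy atoms, each built on a six-membered aromatic ring of carbon only, so the ring's substituents alone can shift the result, even with no hydrogen-bond donors or acceptors on either group. Compound 1 stands at a limit of the assay, not a number, and that ceiling also bounds how much further weakening this series could show as a number: the limit of > 40000 nM in this assay, at which 1 of the 4 values shown sits.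

The step swaps the chlorine and fluorine for an ethyl group in one move, so it cannot say whether losing the halogens or gaining the ethyl matters more. A plain phenyl ring, or a ring carrying only a chlorine or only a methoxy group, would be needed to separate those contributions on this thiourea core.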